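Thiophen-2-yl in place of 3-methoxyphenyl

The source may hold more compounds than are shown below. What is called first, only, known or untested is meant among the compounds shown, and "the series" means these compounds.

Compound 1 `Cn1c(=O)c(=O)n(C2CCCC2)c2nc(N/N=C/c3ccccc3)ncc21`: > 100000 nM (a limit of the assay)
Compound 2 `COc1cccc(/C=N/Nc2ncc3c(n2)n(C2CCCC2)c(=O)c(=O)n3C)c1`: 27400 nM

Among the compounds with values here, in a functional assay on A549 cells (Homo sapiens) for antiproliferative activity, read by MTT assay (a lower number here means a stronger inhibitor, a higher number a weaker inhibitor), compound 2 holds the only actual number of the pair, 27400 nM. Compound 1 reports only a limit of the assay, > 100000 nM.

The next compound, compound 3 `Cn1c(=O)c(=O)n(C2CCCC2)c2nc(N/N=C/c3cccs3)ncc21`, changes the aromatic group of compound 2: thiophen-2-yl in place of 3-methoxyphenyl on a carbon with a double bond to nitrogen. Thiophen-2-yl stands in place of 3-methoxyphenyl on a carbon with a double bond to nitrogen.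

Within the data shown here, one measured step bears on this, an at least 3.6-fold lower number from compound 1 to compound 2 (0.56 log units; beyond the scatter), where methoxy replaced hydrogen on an aromatic carbon. Compound 3 carries no methoxy, so the gain seen in that step may not carry over. Among the measured compounds shown here, the ring itself also changes, and no measured step covers that change directly. A modest step toward a higher number, meaning a weaker result, is therefore expected in this assay. The expected size is a 2.2-fold higher number from compound 2 to compound 3 (0.34 log units; beyond the scatter). The estimate for compound 3 is 60000 nM, with an expected range from 20000 nM to 150000 nM.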

Compound 3, half-maximal inhibitory concentration: > 100000 nM
Compound 3 was reported as a limit; the forecaster's own chance of this, stated with the estimate: 40%; middle value at least 1.6-fold (0.22 log units) away from the limit.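

In this assay, putting thiophen-2-yl in place of 3-methoxyphenyl on a carbon with a double bond to nitrogen gives an at least 3.6-fold higher number from compound 2 to compound 3 (0.56 log units; beyond the scatter), so at this place the five-membered aromatic ring does not keep the measurable activity of the methoxy-bearing six-membered ring. Compound 3 gives > 100000 nM, which is a limit of the assay. Compound 2 therefore remains the only one of the three with an actual number, and the step between the phenyl and thiophen-2-yl compounds cannot be read, because both end at the same limit: the limit of > 100000 nM in this assay, at which 2 of the 3 values shown sit.

On these data alone, the true size of the loss remains open, as does whether a methoxy group on the thiophen-2-yl ring would bring back a measurable number. As far as these compounds go, it is also open whether a furan ring or a pyridine ring at this place, or an ethoxy group on the phenyl ring in place of the methoxy, would give a number like that of compound 2 or fall to the same limit.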